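Lengthening a Saturated Chain by Two Carbons

The compounds below may be only part of what the source reports. "The series", "measured", "known", "first", "only" and "open" are said of these compounds alone.

Compound 1 `CC/C=C/C=C/[C@@]1(C)SC(O)=CC1=O` is measured in a functional assay on MCF7 cells (Homo sapiens) for inhibition, read by radiometric assay and XTT assay; a higher number here means a weaker inhibitor, a lower number a stronger inhibitor. In this assay compound 1 gives only a limit, > 80 ug/mL. Compound 2 `CCCC/C=C/C=C/[C@@]1(C)SC(O)=CC1=O` gives 60 ug/mL. The change between them is ethyl in place of hydrogen on a saturated chain carbon, two bonds along the chain from a double-bonded chain carbon and the step is an at least 1.3-fold lower number from compound 1 to compound 2 (0.12 log units; that floor lies within the scatter); that step is only a floor because of the limit of > 80 ug/mL in this assay, at which 1 of the 3 values shown sits. Compound 3 `C=CCOC1=CC(=O)S[C@]1(C)CCCCCC` gives 9 ug/mL; how its core differs from that of compound 1 is not broken down here. Compound 4 `C=CCOC1=CC(=O)S[C@]1(C)CCCCCCCC` carries the same kind of change on the core of compound 3, (ethyl in place of hydrogen on a saturated chain carbon, six bonds along the chain from a saturated ring carbon), though here the carbon sits six bonds along the chain from a saturated ring carbon rather than two bonds from a double-bonded chain carbon. On the strength of the step from compound 1 to compound 2, the step from compound 3 to compound 4 is expected to be a 1.5-fold lower number from compound 3 to compound 4 (0.18 log units; within the scatter). Compound 4 is therefore estimated at 6 ug/mL, between 2 ug/mL and 20 ug/mL.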

Compound 4, half-maximal inhibitory concentration: 14.5 ug/mL
Compound 4: the middle estimate sits 2.4-fold (0.38 log units) below what was measured, within the range that was stated.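

On the core of compound 3, ethyl in place of hydrogen on a saturated chain carbon, six bonds along the chain from a saturated ring carbon, gives a 1.6-fold higher number from compound 3 to compound 4 (0.21 log units; within the scatter) in this assay, so here the longer chain brings no change that can be told from repeat-measurement noise. Set beside the earlier step, the comparison reaches only this far: the same change on two cores in this assay, an at least 1.3-fold lower number (0.12 log units; that floor lies within the scatter) from compound 1 to compound 2 and a 1.6-fold higher number (0.21 log units; within the scatter) from compound 3 to compound 4; the limit leaves it open whether they differ. This shows that the step on one core gave no clear shift on the other, but it does not show whether the change truly acts alike or differently on the two cores.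

The compounds shown leave open whether a still longer chain would shift the number beyond the scatter on either core. They also leave open what a chain carrying an amine or a carboxylic acid would do.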